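Benzothiazole series: methoxy for fluoro on the aryl ring

A few compounds are considered here, and "the series" means these few. Any claim that something is new, unique, unknown or untested is made for them only; others in the source may bear on it.

Measured so far:
compound 1 `Fc1ccc(/C=N/NC(=S)Nc2nc3ccc(Cl)cc3s2)cc1` — 30 mg/kg
compound 2 `O=C(Cn1ccnc1)Nc1nc2ccc(Cl)cc2s1` — 30 mg/kg

Going by the values given here, in a functional assay on the whole organism with Mus musculus as the target, in the maximal electroshock model, with a stated time of 4 h (on this read-out lower numbers stand for an effect already at smaller amounts and higher numbers for an effect only at larger amounts of compound), compound 1 gives 30 mg/kg and compound 2 gives 30 mg/kg; the two stand level within the scatter, and no step between them is counted. Compound 3 `COc1ccc(/C=N/NC(=S)Nc2nc3ccc(Cl)cc3s2)cc1` differs from compound 1 by methoxy in place of fluoro on an aromatic carbon. Among the compounds with values here, no measured pair isolates this change, so the step of no change at the digits printed from compound 1 to compound 3 (within the scatter) is expected to stay within the scatter, with no direction favoured. Compound 3 is therefore estimated at 30 mg/kg in this assay, expected between 10 mg/kg and 100 mg/kg.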

Compound 3, minimum effective dose: 300 mg/kg
Compound 3: middle estimate off by 10-fold (1.00 log units), on the low side; the measured number lies above the stated range.
By their numbers in this assay, from the lowest: compounds 1 and 2 (each within the scatter of the next); then compound 3.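

At this position, on an aromatic carbon para to a large group, the aryl substituent matters in this assay: going from 4-fluorophenyl to 4-methoxyphenyl gives a 10-fold higher number from compound 1 to compound 3 (1.00 log units; beyond the scatter) with the rest of the structure unchanged. Compounds 1 and 2 differ in more than one place, so they could not isolate any single change. No available measurement accounts for this step.

Going by these compounds, whether the step follows the oxygen or the added carbon remains open. Also open, on these data alone, is how a methyl, an amine or a chloro group at the same place would compare with fluoro and methoxy.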